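Swapping chloro for bromo on the aniline ring of compound 2

A few compounds are considered here, and "the series" means these few. Any claim that something is new, unique, unknown or untested is made for them only; others in the source may bear on it.

Of the compounds shown here, two sharing one core have been measured so far in an assay on tissue (HeLa cells) for inhibition of Indoleamine 2,3-dioxygenase 1 (Homo sapiens), read by spectrophotometry; on this read-out higher numbers stand for weaker inhibition and lower numbers for stronger inhibition. Compound 1 `O/N=C(/Nc1cccc(Br)c1)c1ccc2occc2c1` gives 1100 nM. Compound 2 `O/N=C(/Nc1ccc(F)c(Cl)c1)c1ccc2occc2c1` gives 1800 nM, the higher of the two numbers, though the gap to compound 1 lies within the usual scatter, so the two cannot be told apart. The next compound, compound 3 `O/N=C(/Nc1ccc(F)c(Br)c1)c1ccc2occc2c1`, differs from compound 2 only in one spot: bromo in place of chloro on an aromatic carbon, on an aromatic carbon of a six-membered aromatic ring of carbon only, ortho to a fluoro group and meta to a large group. For the measured compounds named here, no pair of measured compounds shows this exact exchange, so there is no measured step to lean on; the expectation is a step from compound 2 to compound 3 of a 1.3-fold lower number from compound 2 to compound 3 (0.11 log units; within the scatter), that is, no change beyond the scatter. Compound 3 is therefore estimated at 1400 nM, with a plausible range of 600 nM to 3500 nM.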

Compound 3, half-maximal inhibitory concentration: 2600 nM
Compound 3: middle estimate off by 1.9-fold (0.27 log units), on the low side; low and high end bracket the measured number.
By their numbers in this assay, from the lowest: compounds 1, 2 and 3 (each within the scatter of the next, the first and the last beyond it).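

In this assay, exchanging one halogen for the other gives a 1.4-fold higher number from compound 2 to compound 3 (0.16 log units; within the scatter), so at this position, ortho to a fluoro group, the two halogens cannot be told apart. For the compounds shown here, the first step beyond the scatter comes from a different exchange, fluoro in place of hydrogen on an aromatic carbon, which gives a 2.4-fold higher number from compound 1 to compound 3 (0.37 log units; beyond the scatter), a modest but readable sign that a further substituent on this ring can weaken inhibition. Nothing available explains either step.

From the compounds shown here alone, whether a methyl, a methoxy or a nitrile in place of the halogen would shift the number at this position remains open. So does whether fluoro in place of hydrogen would give a similar step in a compound carrying chloro rather than bromo.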